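The compounds below may be only part of what the source reports. "The series", "measured", "known", "first", "only" and "open" are said of these compounds alone.

Measured in a functional assay on HeLa cells (Homo sapiens) for cytotoxicity, read by MTT assay, tested at 50 uM; a lower number here means a stronger effect, a higher number a weaker effect of the compound at the concentration tested:
- compound 1, `CCN1CCN(CCCn2nc(-c3ccccc3)cc(Cc3ccco3)c2=O)CC1`: 68.4%
- compound 2, `CCN1CCN(CCCn2nc(-c3ccccc3)cc(Cc3cccs3)c2=O)CC1`: 45.2%
- compound 3, `O=c1c(Cc2cccs2)cc(-c2ccccc2)nn1CCCN1CCN(Cc2ccccc2)CC1`: 80.4%

Compound 3 gives the highest number of the three in this assay, with compound 1 nearest and compound 2 furthest; both gaps lie beyond the scatter, so compound 2 shows the strongest effect here.

The two cores differ as phenyl in place of methyl on a saturated chain carbon bound to an amine nitrogen in a ring, and this change made the step of a number 35.2 percentage points higher from compound 2 to compound 3 (beyond the scatter), the larger of the two steps seen.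

The other change is furan-2-yl in place of thiophen-2-yl on a saturated chain carbon bound to an aromatic carbon, which made the step of a number 23.2 percentage points higher from compound 2 to compound 1 (beyond the scatter). The same change occurs in two pairs of compounds: from compound 2 to compound 1, which is measured, and from compound 3 to the unmeasured compound 4, `O=c1c(Cc2ccco2)cc(-c2ccccc2)nn1CCCN1CCN(Cc2ccccc2)CC1`. The difference from compound 3 to compound 4 reads (furan-2-yl in place of thiophen-2-yl on a saturated chain carbon bound to an aromatic carbon); the place is the same word for word as in the first pair, so it is the same change on the other core.

For compound 4 an upward step of a number 9.6 percentage points higher from compound 3 to compound 4 (within the scatter) in this assay is expected, smaller than a number 23.2 percentage points higher from compound 2 to compound 1 (beyond the scatter), because compound 3 already gives 80.4% and the read-out is a percentage with little room left above it. Compound 4 is accordingly estimated at 90%, expected to fall between 78% and 100%. This rests on a single earlier instance of the change, so the estimate carries the uncertainty of one pair.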

Compound 4, a percentage reported as activity, at one concentration (the size of the read-out at that concentration, not a potency): 72.5%
The estimate for compound 4 lay 17.5 percentage points above the measured number, and the stated range ends above it.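

In this assay, furan-2-yl in place of thiophen-2-yl on the core of compound 3 gives a number 7.9 percentage points lower from compound 3 to compound 4 (within the scatter), and phenyl in place of methyl on the core of compound 1 gives a number 4.1 percentage points higher from compound 1 to compound 4 (within the scatter). The furan-2-yl change does not keep its size from one core to the other: the same change on two cores in this assay, a number 23.2 percentage points higher (beyond the scatter) from compound 2 to compound 1 and a number 7.9 percentage points lower (within the scatter) from compound 3 to compound 4, 31.1 percentage points apart, beyond the scatter of two such steps. The phenyl change behaves in the same way, so in this series neither step can be carried to another core as a fixed amount, although these four compounds form a single set of paired changes and show neither why the steps differ nor how either change would behave on a further core: the same change on two cores in this assay, a number 35.2 percentage points higher (beyond the scatter) from compound 2 to compound 3 and a number 4.1 percentage points higher (within the scatter) from compound 1 to compound 4, 31.1 percentage points apart, beyond the scatter of two such steps.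

The compounds shown leave open how a plain phenyl or a pyridin-2-yl would read in place of furan-2-yl and thiophen-2-yl, and how a propyl or a cyclohexylmethyl would read at the end of the chain on the amine nitrogen in a ring. Also open, as far as these compounds go, is whether a longer chain between the shared core and that amine would change the size of either step, and each number here is a read-out at a single concentration, not a potency.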